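Swapping an aryl for a benzyl on the amine

A few compounds are considered here, and "the series" means these few. Any claim that something is new, unique, unknown or untested is made for them only; others in the source may bear on it.

Of the compounds shown here, two that share one core have been measured in an assay on HEK293 cells for displacement of a labelled ligand from Urotensin-2 receptor (Homo sapiens); on this read-out higher numbers stand for weaker inhibition and lower numbers for stronger inhibition. Compound 1 `CC(=O)N(CC(=O)N1CCC[C@H](c2ccccc2)[C@@H]1CN1CCCC1)c1ccc(Cl)c(Cl)c1` gives 1580 nM. Among the measured compounds shown here, compound 2 `Cc1ccc(N(C)CC(=O)N2CCC[C@H](c3ccccc3)[C@@H]2CN2CCCC2)cc1C` gives 200 nM, the lower of the two numbers; its only neighbour is compound 1, whose number is higher by an amount beyond the usual scatter of repeated measurements. Compound 3 `CN(CC(=O)N1CCC[C@H](c2ccccc2)[C@@H]1CN1CCCC1)Cc1ccc(Cl)c(Cl)c1` has not yet been measured. It differs from compound 2 in one place: 3,4-dichlorobenzyl in place of 3,4-dimethylphenyl on an amine nitrogen. For the measured compounds named here, no pair of measured compounds shows a step of this kind, so the expectation rests on compound 2 alone and on the fact that the change is more than a swap of substituents on the ring. Compound 3 is expected to come out somewhat weaker, with an expected step of a 3.0-fold higher number from compound 2 to compound 3 (0.48 log units; beyond the scatter). In this assay compound 3 is estimated at 600 nM, within a range of 150 nM to 2500 nM.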

Compound 3, inhibition constant: 3980 nM
Beside the measured number, compound 3's estimate is 6.6-fold (0.82 log units) below it, outside the stated range (above it).
By their numbers in this assay, from the lowest: compound 2; then compound 1; then compound 3.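

In this assay, putting 3,4-dichlorobenzyl in place of 3,4-dimethylphenyl on this amine nitrogen gives a 20-fold higher number from compound 2 to compound 3 (1.30 log units; beyond the scatter) and so shows that inhibition is highly sensitive to the group at this position. The swap is not a single edit: the two methyl groups on the ring become chlorines, and a ring bonded directly to the nitrogen becomes one attached through a benzyl carbon. Nothing measured here gives a reason for the weaker inhibition.

Which of the two edits accounts for the loss remains open, and a 3,4-dimethylbenzyl group on the same nitrogen would help separate them by keeping the methyl groups while adding the benzyl carbon. Whether an unsubstituted benzyl or a longer phenethyl chain could match compound 2 is also unknown.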